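The source may report more compounds than this note shows. Statements on the series, on what has been measured and on what is new or still open speak of the compounds shown alone.

Working notes on the series. The compounds share one core, shown in compound 1 `NC1=NC2(CCOCC2)N(OCCCOc2ccc(Cl)c(Cl)c2)C(N)=N1`, with a chain ending in a substituted phenoxy group. In a functional assay on MDA-MB-231 cells (Homo sapiens) for antiproliferative activity, read by MTT assay, with a stated time of 72 h (a higher number here means a weaker inhibitor, a lower number a stronger inhibitor), compound 1 gives 590 nM. Compound 2 `Cc1ccc(OCCCON2C(N)=NC(N)=NC23CCOCC3)cc1` belongs to the same set, but in this assay compound 2 gives "not determined" (no result reported). Compound 3 `NC1=NC2(CCOCC2)N(OCCCOc2ccc(Cl)cc2)C(N)=N1` likewise in this assay gives "not determined" (no result reported), so compound 3 stands without a number and cannot be placed against compound 1. Compound 4 `NC1=NC2(CCOCC2)N(OCCCOc2ccccc2Cl)C(N)=N1` differs from compound 3 in one place: 2-chlorophenyl in place of 4-chlorophenyl on an oxygen on a saturated carbon. Among the compounds with values here, no measured step of this kind exists in this assay; the change is expected to move this assay only within the usual scatter, or to weaken it modestly. Compound 4 is estimated at 1000 nM, with a range from 300 nM to 4000 nM.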

Compound 4, half-maximal inhibitory concentration: 1430 nM
For compound 4 the middle estimate is 1.4-fold (0.16 log units) below the measured one; the range from low to high includes it.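

In this assay the aryl group at the end of the chain now has a second measured form: 2-chlorophenyl in place of 3,4-dichlorophenyl gives a 2.4-fold higher number from compound 1 to compound 4 (0.38 log units; beyond the scatter), a modest loss that keeps activity measurable. This single step changes both the number and the placement of chlorine, so the two cannot be separated, and steps involving compound 2 or compound 3 cannot be read. Nothing available explains the shift.

Still open, as far as these compounds go, is how a methoxy group or a nitrile on the phenyl ring would compare, or a longer chain.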